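Isothiocyanate-linker variation on the shared core

A few compounds are considered here, and "the series" means these few. Any claim that something is new, unique, unknown or untested is made for them only; others in the source may bear on it.

compound 1 `CN(C)C(=O)c1cc2cnc(Nc3ccc(C(=O)NCCCN=C=S)cc3)nc2n1C1CCCC1`: in a functional assay on A549 cells (Homo sapiens) for inhibition, read by CCK-8 assay, with a stated time of 72 h, tested at 10 uM (on this read-out higher numbers stand for a stronger effect at the one concentration tested and lower numbers for a weaker effect), compound 1 gives 103%
compound 2 `CN(C)C(=O)c1cc2cnc(Nc3ccc(C(=O)NCCCCCCCN=C=S)cc3)nc2n1C1CCCC1`: in this assay compound 2 gives 101%

Both measured compounds sit at complete inhibition at the one concentration tested. Within the data shown here, the single measured step, a number 2 percentage points lower from compound 1 to compound 2 (within the scatter), is within the scatter, so compound 1 and compound 2 cannot be told apart on these numbers; compound 1 simply carries the higher of the two figures, which means nothing here.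

Compound 3 `CN(C)C(=O)c1cc2cnc(Nc3ccc(NC(=O)CCCCCCN=C=S)cc3)nc2n1C1CCCC1` is not yet measured. Relative to compound 1 the change is a group of 12 heavy atoms (8 carbon, 2 nitrogen, 1 oxygen, 1 sulfur; no ring) in place of a group of 9 heavy atoms (5 carbon, 2 nitrogen, 1 oxygen, 1 sulfur; no ring), on an aromatic carbon. Among the measured compounds shown here, the only step that bears on this is the chain lengthening at the isothiocyanate end, a number 2 percentage points lower from compound 1 to compound 2 (within the scatter), which left the read-out unchanged. For the measured compounds named here, the reversal of the amide linkage in compound 3 has no measured counterpart, so nothing is known about its effect; the expectation rests on the chain-length step alone. Compound 3 is therefore expected to show no step beyond the scatter, a number 3 percentage points lower from compound 1 to compound 3 (within the scatter). For compound 3 the estimated value in this assay is 100%, with a range from 88% to 106%.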

Compound 3, a percentage reported as inhibition, at one concentration (the size of the read-out at that concentration, not a potency): 102%
Estimate against measurement, compound 3: 2 percentage points below, within the range that was stated.
By their numbers in this assay, from the lowest: compounds 2, 3 and 1 (each within the scatter of the next).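

Working notes on the group on the aromatic carbon, para to a large group: in this assay the exchange of the group of 9 heavy atoms for the group of 12 heavy atoms gives a number 1 percentage points lower from compound 1 to compound 3 (within the scatter), so the inhibition stays complete at the one concentration tested. Unlike the earlier step, which only lengthened the chain at the isothiocyanate end, this change also reverses the amide linkage, and the series now shows complete inhibition with the linkage in either direction, the chain length differing as well. No measured information on hand accounts for this result.

All three compounds sit at complete inhibition at a single concentration, so the read-out gives no potency, and any difference between the two amide directions or the chain lengths could only appear at lower concentrations. Also open, going by these compounds, is how much of the inhibition depends on the isothiocyanate itself, which a chain ending in a simple amine or a carboxylic acid on the same core would test.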